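The compounds below may be only part of what the source reports. "The series", "measured", "known", "first", "only" and "open" are said of these compounds alone.

Compound 1, `Cc1ccc(NC(=O)Nc2ccc(Cl)cc2)cc1S(=O)(=O)N(C)C`: 3300 nM
Compound 2, `Cc1ccc(NC(=O)Nc2ccc(C)c(S(=O)(=O)N(C)C)c2)cc1Cl`: 2900 nM
Compound 3, `Cc1ccc(NC(=O)Nc2ccccc2F)cc1S(=O)(=O)N(C)C`: 3900 nM

In an assay on HEK293 cells for activation of Kir3.1/Kir3.2 (Homo sapiens), read by fluorescence and thallium flux, with a stated time of 4 min (on this read-out higher numbers stand for an effect only at larger amounts of compound and lower numbers for an effect already at smaller amounts), the three compounds sit close together. For the measured compounds named here, compound 3 is the one whose number is nominally the largest of the three, but its separation from compound 1 is only a 1.2-fold higher number from compound 1 to compound 3 (0.07 log units; within the scatter) and from compound 2 only a 1.3-fold higher number from compound 2 to compound 3 (0.13 log units; within the scatter), so the three cannot be told apart on these measurements; the remaining pair gives a 1.1-fold lower number from compound 1 to compound 2 (0.06 log units; within the scatter).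

Compound 4, `Cc1ccc(NC(=O)Nc2ccccc2Cl)cc1S(=O)(=O)N(C)C`, differs from compound 3 in one place: chloro in place of fluoro on an aromatic carbon. All three measured steps bear on it in the sense that each also varies only the aryl ring on the amide-type nitrogen, and each of them stayed within the scatter, whether the change was a shift of substituent pattern or an exchange of halogen for halogen and methyl. Going by the values given here, no measured step exchanges fluoro for chloro at this same position, so the step from compound 3 to compound 4 has no direct precedent. On the evidence of the measured steps, the step expected in this assay is estimated as a 1.0-fold lower number from compound 3 to compound 4 (0.01 log units; within the scatter). Compound 4 is therefore estimated at 3800 nM, with a range from 1900 nM to 7600 nM.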

Compound 4, half-maximal effective concentration: 2700 nM
Compound 4: middle estimate off by 1.4-fold (0.15 log units), on the high side, and the stated range covers the measured number.
By their numbers in this assay, from the lowest: compounds 4, 2, 1 and 3 (each within the scatter of the next).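

In this assay, for the compounds shown here, the exchange of fluoro for chloro on an aromatic carbon ortho to a large group gives a 1.4-fold lower number from compound 3 to compound 4 (0.16 log units; within the scatter) and so adds a direct halogen-for-halogen comparison at one place, which the earlier compounds lacked; at this position, the two halogens cannot be told apart on these measurements. Going by these compounds alone, the 2-chlorophenyl group also gives a 1.2-fold lower number from compound 1 to compound 4 (0.09 log units; within the scatter) when it replaces 4-chlorophenyl, showing for the first time that the same halogen at these two named positions leaves the number within the scatter. Replacing 3-chloro-4-methylphenyl with 2-chlorophenyl likewise gives a 1.1-fold lower number from compound 2 to compound 4 (0.03 log units; within the scatter) and so extends the flat picture across all four compounds, while nothing shown offers an explanation for this result.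

The compounds shown leave open whether an amine, a carboxylic acid or a methoxy group in place of the halogen on this ring would give a number beyond the scatter. They also leave open whether the same flat picture would hold if the dimethylamino group on the sulfonyl of the shared core were exchanged for a longer chain.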